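Swapping the carboxyphenyl arm for a methylpyridyl ring

The compounds below may be only part of what the source reports. "The series", "measured", "known", "first", "only" and "open" are said of these compounds alone.

Three compounds share one core, and compound 2 `O=C(O)c1ccc(-c2cnc(C(=O)CCCCCCc3ccccc3)o2)cc1` gives the highest of the three numbers in an assay (Rattus norvegicus) for inhibition of Fatty-acid amide hydrolase 1 (Homo sapiens) (a lower number here means a stronger inhibitor, a higher number a weaker inhibitor), at 60 nM. Compound 1 `COC(=O)c1ccc(-c2cnc(C(=O)CCCCCCc3ccccc3)o2)cc1` gives 40 nM, and compound 3 `NS(=O)(=O)c1ccc(-c2cnc(C(=O)CCCCCCc3ccccc3)o2)cc1` gives 10 nM. The step of a 1.5-fold higher number from compound 1 to compound 2 (0.18 log units; within the scatter) was within the scatter, whereas a 6.0-fold lower number from compound 2 to compound 3 (0.78 log units; beyond the scatter) and a 4.0-fold lower number from compound 1 to compound 3 (0.60 log units; beyond the scatter) were modest. Compound 4 `Cc1cccc(-c2cnc(C(=O)CCCCCCc3ccccc3)o2)n1` carries a different change: 6-methylpyridin-2-yl in place of 4-carboxyphenyl on an aromatic carbon. Among the compounds with values here, none of the measured steps replaces the whole aromatic arm, so they bear on it only loosely; the ester of compound 1 and the acid of compound 2 giving similar numbers suggests the carboxy group is not decisive. A small step in either direction, or none beyond the scatter, is expected: a 1.5-fold lower number from compound 2 to compound 4 (0.18 log units; within the scatter). Compound 4 is therefore estimated at 40 nM, in the range 10 nM to 200 nM.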

Compound 4, inhibition constant: 3.3 nM
Compound 4: middle estimate off by 12-fold (1.08 log units), on the high side; the whole stated range lies above it.
By their numbers in this assay, from the lowest: compound 4; then compound 3; then compounds 1 and 2 (each within the scatter of the next).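

In this assay, within the data shown here, the step of an 18-fold lower number from compound 2 to compound 4 (1.26 log units; beyond the scatter) is large, whereas the earlier compounds, which all keep a carbon-only aromatic ring, showed only modest steps or none beyond the scatter. This position on the shared core therefore tolerates replacement of the whole aromatic arm, and compound 4 has the lowest number of the four. Nothing given here explains this gain. The ring atom, methyl group and carboxy group all change together. As far as these compounds go, the contribution of each remains open. An unsubstituted pyridin-2-yl ring or a plain phenyl ring would begin to separate them.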